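Benzamide Variation on a Shared Thiazole Amide Series

The compounds below may be only part of what the source reports. "The series", "measured", "known", "first", "only" and "open" are said of these compounds alone.

Compound 3 `CCOC(=O)c1sc(-c2cccc(NC(=O)c3ccccc3F)c2)nc1Nc1ccc(N2CCN(C)CC2)cc1`: 2000 nM
Compound 1 `CCOC(=O)c1sc(-c2cccc(NC(=O)c3ccc(C(F)(F)F)cc3)c2)nc1Nc1ccc(N2CCN(C)CC2)cc1`: "not determined" (no result reported)
Compound 2 `CCOC(=O)c1sc(-c2cccc(NC(=O)c3ccc(C(C)(C)C)cc3)c2)nc1Nc1ccc(N2CCN(C)CC2)cc1`: "not determined" (no result reported)

Three compounds share the same core and differ only in the aryl group on the amide carbonyl. In a functional assay on Ramos cells (Homo sapiens) for antiproliferative activity, read by CCK-8 assay, with a stated time of 72 h (a higher number here means a weaker inhibitor, a lower number a stronger inhibitor), compound 3 gives 2000 nM. Among the compounds with values here, this is the only number available: compound 1, which carries a trifluoromethyl group on its benzamide ring, gives "not determined" (no result reported) in this assay, and compound 2, which carries a tert-butyl group on its benzamide ring, gives "not determined" (no result reported) in this assay, so nothing can be said about how those groups compare with compound 3.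

Compound 4 `CCOC(=O)c1sc(-c2cccc(NC(=O)c3ccc(F)c(Cl)c3)c2)nc1Nc1ccc(N2CCN(C)CC2)cc1` is the next compound in the set. Its change from compound 3 is 3-chloro-4-fluorophenyl in place of 2-fluorophenyl on a carbonyl carbon. Within the data shown here, no step between measured compounds is available to calibrate what such a change does here, and the two compounds that would have framed a pattern across the benzamide ring carry no number. The expectation therefore rests on compound 3 alone, and the step from compound 3 to compound 4 is expected to be small, no larger than the scatter of this assay, as a 1.3-fold lower number from compound 3 to compound 4 (0.12 log units; within the scatter) expresses. Compound 4 is estimated at 1500 nM in this assay, within a wide range from 400 nM to 6000 nM.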

Compound 4, half-maximal inhibitory concentration: 29200 nM
For compound 4 the middle estimate is 19-fold (1.29 log units) below the measured one; measured number outside the range, above it.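

The aryl group on this carbonyl carbon proves not to be a silent position: in this assay the swap of 2-fluorophenyl for 3-chloro-4-fluorophenyl gives a 15-fold higher number from compound 3 to compound 4 (1.16 log units; beyond the scatter) and leaves compound 4 the weaker inhibitor of the two. Within the data shown here, this is the only step that can be read in the set, and it shows that changing the substituents on this ring alone can move the number well beyond the scatter, while the shared core stays the same. The two groups have the same count of hydrogen-bond donors and acceptors and neither carries a net charge, and nothing given here explains the size of this step.

On these data alone, the step changes the ring in more than one way at once, adding a chlorine and placing the fluorine differently, so it remains open which of these goes with the higher number, and 4-fluorophenyl or 3-chlorophenyl on the same carbonyl carbon would be needed to separate them. Steps involving compound 1 and compound 2 cannot be read, and it also remains open what an amine or a carboxylic acid on this ring would give.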